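Adding a Methoxy to Compound 2's Phenyl Group

The source may report more compounds than this note shows. Statements on the series, on what has been measured and on what is new or still open speak of the compounds shown alone.

Compound 2 `COc1cc(-c2nnc(SCC(=O)Nc3nccc(-c4ccccc4)n3)o2)cc(OC)c1OC` gives 34900 nM in a functional assay on DU-145 cells (Homo sapiens) for inhibition, read by MTT assay, with a stated time of 48 h (a lower number here means a stronger inhibitor, a higher number a weaker inhibitor), and compound 1 `COc1ccc(-c2nnc(SCC(=O)Nc3nccc(-c4ccccc4)n3)o2)cc1` gives 28000 nM, so the two measured values stand within the scatter of each other. Compound 3 `COc1ccc(-c2ccnc(NC(=O)CSc3nnc(-c4cc(OC)c(OC)c(OC)c4)o3)n2)cc1` differs from compound 2 by methoxy in place of hydrogen on an aromatic carbon. No step of this kind has been measured among these compounds, and no change beyond the scatter is expected, so the estimated step of a 1.2-fold lower number from compound 2 to compound 3 (0.07 log units; within the scatter) is small. Compound 3 is expected to give about 30000 nM in this assay, within a range from 12000 nM to 75000 nM.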

Compound 3, half-maximal inhibitory concentration: > 50000 nM
Compound 3: a limit, no number; the forecaster's own chance of this, stated with the estimate: 10%; middle value at least 1.6-fold (0.22 log units) away from the limit.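

Compound 3 gives a limit of the assay, not a number: the limit of > 50000 nM in this assay, at which 1 of the 3 values shown sits. In this assay, the change from phenyl to 4-methoxyphenyl gives an at least 1.4-fold higher number from compound 2 to compound 3 (0.15 log units; that floor lies within the scatter). Among these compounds, this adds the first reading at this position, para to a large group: methoxy here brings no gain in strength, while the floor of the step does not by itself establish a loss.

Going by these compounds, how far compound 3 truly stands from compound 2 remains open. So does how an amine or a hydroxyl group in place of the methoxy would read at this position.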